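The source may report more compounds than this note shows. Statements on the series, on what has been measured and on what is new or still open speak of the compounds shown alone.

Measured compounds:
compound 1 `CCCN(CCC)c1nc(C)nc2c(-c3c(C)cc(N(C)C)nc3C)c(C)nn12`, 14.9 nM
compound 2 `CCCCN(CCC)c1nc(C)nc2c(-c3ccc(OC)nc3C)c(C)nn12`, 2.4 nM
compound 3 `CCC(CC)Nc1nc(C)nc2c(-c3cnc(N(C)C)cc3C)c(C)nn12`, 24.8 nM

All three were tested in an assay on cell membranes for displacement of a labelled ligand from corticotropin-releasing factor receptor 1 (Rattus norvegicus); a higher number here means a weaker inhibitor, a lower number a stronger inhibitor. Compound 2 gives the lowest number of the three. Compound 1 and compound 3 both return higher numbers, and each of those gaps lies beyond the usual scatter, so compound 2 stands as the strongest inhibitor in this set.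

Compound 4 `CCCN(CCC)c1nc(C)nc2c(-c3ccc(OC)nc3C)c(C)nn12` differs from compound 2 in a single place: hydrogen in place of methyl on a saturated chain carbon, three bonds along the chain from a nitrogen on an aromatic ring, which read one bond further out is butyl to propyl. Within the data shown here, no measured pair shows this change alone. Compound 1 does carry the dipropylamino group that compound 4 would have, but its aryl ring also differs from that of compound 2, so its value cannot be read as a measure of this one change. Shortening a chain by a single carbon at this position is expected to produce, in this assay, at most a small shift, most likely within the scatter, with a slight weakening if any. Compound 4 is therefore estimated at 3.5 nM, with a range of 1.5 nM to 9 nM, an expected step of a 1.5-fold higher number from compound 2 to compound 4 (0.16 log units; within the scatter).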

Compound 4, half-maximal inhibitory concentration: 5.7 nM
Compound 4: middle estimate off by 1.6-fold (0.21 log units), on the low side; low and high end bracket the measured number.
By their numbers in this assay, from the lowest: compound 2; then compound 4; then compounds 1 and 3 (each within the scatter of the next).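

In this assay, among these compounds, replacing butyl with propyl gives a 2.4-fold higher number from compound 2 to compound 4 (0.38 log units; beyond the scatter), the first step in this set that isolates a single change. It shows that this position on the chain is not indifferent to length, since removing the end methyl moves the number beyond the scatter, though only modestly, and the longer butyl chain goes with the lower number in this one pair. Nothing available here explains the size or direction of this step.

From the compounds shown here alone, whether a longer chain such as pentyl, or a ring-bearing chain such as cyclopropylmethyl, would lower the number further at this position remains open. Among the compounds shown here, it is also open whether the change from butyl to propyl gives a step of similar size when the aryl ring is the one carried by compound 1 or compound 3.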